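The compounds below may be only part of what the source reports. "The series", "measured", "known", "first", "only" and "open" are said of these compounds alone.

Measured so far in a functional assay on HTB-54 cells (Homo sapiens) for cytotoxicity, read by MTT assay, with a stated time of 72 h; on this read-out lower numbers stand for stronger inhibition of growth and higher numbers for weaker inhibition of growth:

- compound 1, `CCOC(=O)Nc1ccc([Se][Se]c2ccc(NC(=O)OCC)cc2)cc1`: 31200 nM
- compound 2, `CC(C)COC(=O)Nc1ccc([Se]C#N)cc1`: 27100 nM
- compound 3, `CCCCCCOC(=O)Nc1ccc([Se][Se]c2ccc(NC(=O)OCCCCCC)cc2)cc1`: 31000 nM

Compound 2 carries the lowest of the three numbers in this assay, but its gaps to compound 3 and to compound 1 are both within the usual scatter, so the three measured compounds cannot be separated on these numbers; no ordering among them is claimed. Among the measured compounds shown here, compound 1 and compound 3 share one kind of core, compound 2 another, and no pairwise step between measured compounds is available.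

Compound 4, `CCOC(=O)Nc1ccc([Se]C#N)cc1`, keeps the core of compound 2 and differs from it only in the change (methyl in place of isopropyl on a saturated chain carbon bound to an oxygen next to a carbonyl group). For the measured compounds named here, no measured pair shows the effect of this change in this assay, so there is no basis for expecting a step beyond the scatter in either direction. The number for compound 4 is therefore expected to stay close to that of compound 2, because compound 2 gives 27100 nM. The step from compound 2 to compound 4 is estimated at a 1.0-fold higher number from compound 2 to compound 4 (0.01 log units; within the scatter). For compound 4 the estimate in this assay is 28000 nM, with a range from 12000 nM to 65000 nM.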

Compound 4, concentration for 50% growth inhibition: 24900 nM
For compound 4 the middle estimate is 1.1-fold (0.05 log units) above the measured one; measured number inside the range.
By their numbers in this assay, from the lowest: compounds 4, 2, 3 and 1 (each within the scatter of the next).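

Among the compounds shown here, this is the only pair that differs in one place: on a saturated chain carbon bound to an oxygen next to a carbonyl group, methyl in place of isopropyl gives a 1.1-fold lower number from compound 2 to compound 4 (0.04 log units; within the scatter) in this assay and so leaves the two compounds indistinguishable on this read-out. On the core of compound 2, isobutoxy and ethoxy therefore cannot be told apart at this place, a reading that rests on this single pair. No supporting data bear on why the two compounds read alike.

Still open, from the compounds shown here alone, is whether any group at this place moves the number beyond the scatter, such as an amine or a carboxylic acid on the chain. Also open, going by these compounds, is whether isobutoxy and ethoxy would read alike on the core of compound 1.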